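Amide nitrogen substituent series: estimate for compound 4

This account rests on a few compounds, and the source may have more. Where it says the series, first, only, none or still open, it means among the compounds named here.

compound 1 `CCCNC(=O)c1ccc(Oc2nc(-c3c(C)noc3C)cnc2N)cc1` — 47800 nM
compound 2 `Cc1noc(C)c1-c1cnc(N)c(Oc2ccc(C(=O)Nc3ccccc3Cl)cc2)n1` — 60500 nM
compound 3 `Cc1noc(C)c1-c1cnc(N)c(Oc2ccc(C(=O)Nc3ccc(Cl)cc3)cc2)n1` — 15500 nM

In a functional assay on U-87MG ATCC cells for inhibition, with U-87 MG (Homo sapiens) as the target, read by MTT assay, with a stated time of 72 h (on this read-out lower numbers stand for stronger inhibition and higher numbers for weaker inhibition), compound 3 gives the lowest number of the three: the steps of a 3.1-fold lower number from compound 1 to compound 3 (0.49 log units; beyond the scatter) and a 3.9-fold lower number from compound 2 to compound 3 (0.59 log units; beyond the scatter) both lie beyond the scatter, whereas a 1.3-fold higher number from compound 1 to compound 2 (0.10 log units; within the scatter) does not. Compound 4 `Cc1noc(C)c1-c1cnc(N)c(Oc2ccc(C(=O)Nc3ccc(Cl)cn3)cc2)n1` differs from compound 3 by 5-chloropyridin-2-yl in place of 4-chlorophenyl on an amide-type nitrogen. For the measured compounds named here, none of the measured steps exchanges a ring carbon for a ring nitrogen; they compare propyl with chlorophenyl rings, so they bear only indirectly on this change. The chlorophenyl of compound 3 stays the better of the two measured aryl amides, and the new ring keeps its substitution pattern, so compound 4 is expected to show a step of a 1.0-fold lower number from compound 3 to compound 4 (0.01 log units; within the scatter), within the scatter. The estimate for compound 4 is 15000 nM, with a range from 5000 nM to 45000 nM.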

Compound 4, half-maximal inhibitory concentration: 45600 nM
Compound 4: the middle estimate sits 3.0-fold (0.48 log units) below what was measured; the measured number lies above the stated range.
By their numbers in this assay, from the lowest: compound 3; then compounds 4, 1 and 2 (each within the scatter of the next).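

At the amide-type nitrogen, one ring nitrogen in place of a ring carbon is enough to move the number: a 2.9-fold higher number from compound 3 to compound 4 (0.47 log units; beyond the scatter) follows from that exchange alone. With a 1.3-fold lower number from compound 2 to compound 4 (0.12 log units; within the scatter) and a 1.0-fold lower number from compound 1 to compound 4 (0.02 log units; within the scatter) compound 4 falls in with the propyl and 2-chlorophenyl amides, so among these four compounds only the 4-chlorophenyl of compound 3 stands apart. No measurement at hand accounts for this step. Still open, as far as these compounds go, is whether an unsubstituted phenyl, a fluorophenyl or a pyridin-3-yl ring on this nitrogen would stay with compound 3 or go with compound 4.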